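This account rests on a few compounds, and the source may have more. Where it says the series, first, only, none or still open, it means among the compounds named here.

Compound 1 `COc1ccc(/C=C/C(=O)Nc2cc(C(=O)c3cc(OC)c(OC)c(OC)c3)ccc2OC)cc1` shares its core with compound 2 `C#CCOc1cccc(/C=C/C(=O)Nc2cc(C(=O)c3cc(OC)c(OC)c(OC)c3)ccc2OC)c1` and compound 3 `COc1ccc(C(=O)c2cc(OC)c(OC)c(OC)c2)cc1NC(=O)/C=C/c1cccc(OC(F)(F)F)c1`. In a functional assay on DU-145 cells (Homo sapiens) for cytotoxicity, read by MTT assay, with a stated time of 72 h (on this read-out lower numbers stand for stronger inhibition and higher numbers for weaker inhibition), compound 1 gives 12800 nM, the second highest of the three numbers. Compound 2 gives 15800 nM and compound 3 gives 10200 nM. The measured steps are all small: a 1.2-fold higher number from compound 1 to compound 2 (0.09 log units; within the scatter), a 1.3-fold lower number from compound 1 to compound 3 (0.10 log units; within the scatter) and a 1.5-fold lower number from compound 2 to compound 3 (0.19 log units; within the scatter), each within the scatter. Compound 4 `COc1ccc(/C=C/C(=O)Nc2cc(C(=O)c3cc(OC)c(OC)c(OC)c3)cc(OC)c2OC)cc1` differs from compound 1 by methoxy in place of hydrogen on an aromatic carbon. Among the compounds with values here, no measured step touches that part of the core, so there is no direct guide, and the steps that do exist stayed within the scatter. Compound 4 is therefore expected to give about 12800 nM, between 4000 nM and 40000 nM. That estimate means no change at the digits printed from compound 1 to compound 4 (within the scatter), so no step beyond the scatter is expected.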

Compound 4, half-maximal inhibitory concentration: 10400 nM
For compound 4 the middle estimate is 1.2-fold (0.09 log units) above the measured one; measured number inside the range.
By their numbers in this assay, from the lowest: compounds 3, 4, 1 and 2 (each within the scatter of the next).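

In this assay, methoxy in place of hydrogen on this aromatic carbon, ortho to a methoxy group, gives a 1.2-fold lower number from compound 1 to compound 4 (0.09 log units; within the scatter). Within the data shown here, the earlier compounds differ only in another place, so this is the first sign that this position accepts a methoxy group with no change beyond the scatter. Nothing available explains this result. Only hydrogen and methoxy are compared at this position, so an amine, a carboxylic acid or a longer chain here could behave differently. On these data alone, whether methoxy gives the same result alongside the groups in compound 2 or compound 3 also remains open.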